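Changing the aryl group on the ring amine nitrogen

The compounds below may be only part of what the source reports. "The series", "measured", "known", "first", "only" and "open" are said of these compounds alone.

Measured compounds and their half-lives:
compound 1: `O=C(NCCCCN1CCN(c2ccc(Cl)cc2)CC1)c1ccc(-c2ccsc2)cc1`, 0.837 h
compound 2: `O=C(NCCCCN1CCN(c2cccc(O)c2)CC1)c1ccc(-c2ccsc2)cc1`, 0.085 h
compound 3: `Cc1cccc(N2CCN(CCCCNC(=O)c3ccc(-c4ccsc4)cc3)CC2)c1`, 0.372 h

These three compounds share one core and differ only in the substituted phenyl attached to an amine nitrogen in a ring. In an ADME assay on microsomes from liver (Rattus norvegicus) for metabolic stability, read by LC-MS, using NADPH (a lower number here means that the compound disappears faster, a higher number that the compound lasts longer), compound 3 gives 0.372 h, the second highest of the three numbers. Compound 3 sits between the other two: the step of a 2.3-fold lower number from compound 1 to compound 3 (0.35 log units; beyond the scatter) separates it from compound 1, and the step of a 4.4-fold higher number from compound 2 to compound 3 (0.64 log units; beyond the scatter) separates it from compound 2.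

Compound 4, `N#Cc1ccccc1N1CCN(CCCCNC(=O)c2ccc(-c3ccsc3)cc2)CC1`, has not yet been measured in this assay. Its change from compound 3 is 2-cyanophenyl in place of 3-methylphenyl on an amine nitrogen in a ring. Among the compounds with values here, two measured steps concern the same position and are the best guide: a 9.8-fold lower number from compound 1 to compound 2 (0.99 log units; beyond the scatter) and a 2.3-fold lower number from compound 1 to compound 3 (0.35 log units; beyond the scatter). Each swapped one substituted phenyl for another and moved the half-life by a modest amount, once sharply downward and once mildly downward. A nitrile has not been tried in this series, so the direction for compound 4 is uncertain, but the spread among the three compounds suggests a modest move rather than a large one. The half-life of compound 4 in this assay is expected near 0.5 h, within a range from 0.2 h to 1.2 h. That estimate corresponds to an expected step of a 1.3-fold higher number from compound 3 to compound 4 (0.13 log units; within the scatter).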

Compound 4, half-life: 0.0333 h
Compound 4: middle estimate off by 15-fold (1.18 log units), on the high side; the whole stated range lies above it.
By their numbers in this assay, from the lowest: compound 4; then compound 2; then compound 3; then compound 1.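

In this assay, 2-cyanophenyl gives the shortest half-life of the four compounds, with an 11-fold lower number from compound 3 to compound 4 (1.05 log units; beyond the scatter) and a 2.6-fold lower number from compound 2 to compound 4 (0.41 log units; beyond the scatter) and also a 25-fold lower number from compound 1 to compound 4 (1.40 log units; beyond the scatter) as the steps that set it apart. This extends the low end of the range at this position, which compound 2 had held with its 3-hydroxyphenyl group, so a hydroxy group on the phenyl is not required for a half-life this short, and the choice of substituted phenyl on the ring amine nitrogen can matter more than the first three compounds showed. No measurement shown here explains why the nitrile-bearing compound disappears so quickly.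

The four compounds differ both in the substituent and in where it stands on the phenyl, so the effect of the nitrile itself cannot be separated from the effect of its place on the ring. From the compounds shown here alone, how a methoxy group or a fluorine atom on the phenyl would compare, and whether the same group moved around the ring would shift the half-life, remains open.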